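Chloro gives way to methoxy on a shared core

A few compounds are considered here, and "the series" means these few. Any claim that something is new, unique, unknown or untested is made for them only; others in the source may bear on it.

Measured so far in a functional assay on MOLT-4 cells (Homo sapiens) for inhibition (a higher number here means a weaker inhibitor, a lower number a stronger inhibitor), for two compounds:
Compound 1 `COc1cccc(/C=C2\Cc3ccccc3C2=O)c1` gives > 500000 nM as a limit
Compound 2 `O=C1/C(=C/c2ccc(Cl)cc2)CCCc2ccccc21` gives 33000 nM as a number

The reading for compound 1 is a limit and not a number. Among the compounds with values here, that leaves compound 2 with the only true number in the set, so no measured step can be read from these data. Compound 3 `COc1ccc(/C=C2\CCCc3ccccc3C2=O)cc1` keeps the core of compound 2 but has a change methoxy in place of chloro on an aromatic carbon in which methoxy stands in place of chloro on an aromatic carbon, para to a large group. Within the data shown here, with no measured step to guide it, only a modest change is expected in this assay towards weaker inhibition, perhaps little beyond the scatter. The estimate implies an expected 1.4-fold higher number from compound 2 to compound 3 (0.13 log units; within the scatter) in that direction. Compound 3 is expected at 45000 nM within an estimated range of 12000 nM to 170000 nM in this read-out.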

Compound 3, half-maximal inhibitory concentration: 470 nM
Compound 3: the middle estimate sits 96-fold (1.98 log units) above what was measured, and the stated range ends above it.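

In this assay, the step at this aromatic carbon, para to a large group, is a 70-fold lower number from compound 2 to compound 3 (1.85 log units; beyond the scatter), so on the shared core this position is far from indifferent to the group it carries. Compound 2 alone could not show this: a single number says nothing about how far the reading moves when the group there changes, and methoxy in place of chloro proves to be a change of large size. Compound 1 stays outside the comparison, as it differs from the other two in more than one place and its reading is a limit and not a number: the limit of > 500000 nM in this assay, at which 1 of the 3 values shown sits.

The compounds shown leave open whether this step is particular to methoxy or would also come with other groups at this place, such as a hydroxyl, an ethoxy group or an amine. They also leave open whether methoxy in place of chloro would give a step of this size on another core.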